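Furan-2-yl for thiophen-2-yl on the shared core

The compounds below may be only part of what the source reports. "The series", "measured", "known", "first", "only" and "open" are said of these compounds alone.

In a functional assay on HCT-116 cells (Homo sapiens), read by MTT assay, with a stated time of 3 days (a lower number here means a stronger inhibitor, a higher number a weaker inhibitor), compound 1 `CNc1ncnc2[nH]cc(Sc3cccs3)c12` gives 19000 nM, compound 2 `Nc1ncnc2[nH]cc(Sc3cccs3)c12` gives 22800 nM and compound 3 `c1csc(Sc2c[nH]c3ncnc(-c4cccs4)c23)c1` gives 13000 nM. Compound 3 is not separated from either of the other two, since a 1.5-fold lower number from compound 1 to compound 3 (0.16 log units; within the scatter) and a 1.8-fold lower number from compound 2 to compound 3 (0.24 log units; within the scatter) both lie within the scatter.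

Compound 4 `c1coc(-c2ncnc3[nH]cc(Sc4cccs4)c23)c1` differs from compound 3 in one place: furan-2-yl in place of thiophen-2-yl on an aromatic carbon, (furan-2-yl in place of thiophen-2-yl on an aromatic carbon). Among the compounds with values here, no measured pair makes this exchange. The closest evidence is the two steps above, which put thiophen-2-yl on that aromatic carbon in place of methylamino or amino, together with a 1.2-fold higher number from compound 1 to compound 2 (0.08 log units; within the scatter), also within the scatter. Across these three compounds, no change has moved the number beyond the scatter, so no step beyond the scatter is expected in this assay here.

The expected step is a 1.1-fold higher number from compound 3 to compound 4 (0.03 log units; within the scatter). The estimate for compound 4 is 14000 nM, with an expected range of 6500 nM to 30000 nM.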

Compound 4, half-maximal inhibitory concentration: 6750 nM
The estimate for compound 4 lay 2.1-fold (0.32 log units) above the measured number; the measured number falls inside the stated range.
By their numbers in this assay, from the lowest: compounds 4, 3, 1 and 2 (each within the scatter of the next, the first and the last beyond it).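

In this assay, furan-2-yl in place of thiophen-2-yl gives a 1.9-fold lower number from compound 3 to compound 4 (0.28 log units; within the scatter) and so does not separate the two groups at this aromatic carbon. Furan-2-yl is still the first group here to stand beyond the scatter from the amino and methylamino compounds, with a 3.4-fold lower number from compound 2 to compound 4 (0.53 log units; beyond the scatter) and a 2.8-fold lower number from compound 1 to compound 4 (0.45 log units; beyond the scatter) as modest steps. Thiophen-2-yl stayed within the scatter of both, so the two ring groups differ in how they read against those compounds, though not measurably from each other.

On these data alone, whether phenyl or morpholine at this carbon would widen the modest gap from the amino and methylamino compounds remains open. Nothing available accounts for any of these steps.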